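This account rests on a few compounds, and the source may have more. Where it says the series, first, only, none or still open, it means among the compounds named here.

Measured compounds:
Compound 1, `Oc1ccccc1-c1cc(-c2ccccc2F)cc(-c2ccccc2O)n1`. In a functional assay on HCT-15 cells (Homo sapiens) for inhibition (a lower number here means a stronger inhibitor, a higher number a weaker inhibitor), compound 1 reports only a limit, > 50000 nM.
Compound 2, `Oc1cccc(-c2cc(-c3ccccc3F)cc(-c3ccccc3O)n2)c1`. In this assay compound 2 gives 8470 nM.
Compound 3, `Oc1cccc(-c2cc(-c3ccccc3C(F)(F)F)cc(-c3ccccc3O)n2)c1`. In this assay compound 3 gives 9010 nM.

The change from compound 1 to compound 2, (3-hydroxyphenyl in place of 2-hydroxyphenyl on an aromatic carbon), gave an at least 5.9-fold lower number from compound 1 to compound 2 (0.77 log units; beyond the scatter); the step is a bound only, because compound 1 sits at the limit of > 50000 nM in this assay, at which 1 of the 3 values shown sits. From compound 2 to compound 3 there was a 1.1-fold higher number from compound 2 to compound 3 (0.03 log units; within the scatter). Compound 4, `Oc1cccc(-c2cc(-c3ccccc3C(F)(F)F)cc(-c3cccc(O)c3)n2)c1`, awaits measurement. It carries the same kind of change, (3-hydroxyphenyl in place of 2-hydroxyphenyl on an aromatic carbon), though the surroundings differ: the ring here bears a 2-(trifluoromethyl)phenyl group and a 3-hydroxyphenyl group rather than a 2-fluorophenyl group and a 2-hydroxyphenyl group. The difference between the cores of compound 1 and compound 3 is not broken down here. Resting on an at least 5.9-fold lower number from compound 1 to compound 2 (0.77 log units; beyond the scatter), a step of similar size is expected, a 5.0-fold lower number from compound 3 to compound 4 (0.70 log units; beyond the scatter). Compound 4 is estimated at 1800 nM, between 500 nM and 6000 nM.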

Compound 4, half-maximal inhibitory concentration: 8150 nM
For compound 4 the middle estimate is 4.5-fold (0.66 log units) below the measured one, outside the stated range (above it).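

In this assay, placing 3-hydroxyphenyl in place of 2-hydroxyphenyl did not carry over as a transferable gain, with a 1.1-fold lower number from compound 3 to compound 4 (0.04 log units; within the scatter). The same change therefore behaves differently on the two cores: the same change on two cores in this assay, an at least 5.9-fold lower number (0.77 log units; beyond the scatter) from compound 1 to compound 2 and a 1.1-fold lower number (0.04 log units; within the scatter) from compound 3 to compound 4, at least 5.3-fold (0.72 log units) apart, beyond the scatter of two such steps. As far as these compounds go, compound 1 gives only a limit, > 50000 nM; the true size of the earlier step stays unknown, and nothing here shows which difference between the two cores decides the outcome.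

Still open, from the compounds shown here alone, is whether the change would behave as it did on the core of compound 1 or the core of compound 3 on any further core. Also open, going by these compounds, is how an amine or a carboxylic acid in place of the hydroxyl on these phenyl groups would read in this assay.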